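Trifluoromethylphenyl Replaces Chlorophenyl on a Shared Core

A few compounds are considered here, and "the series" means these few. Any claim that something is new, unique, unknown or untested is made for them only; others in the source may bear on it.

The three measured compounds share one core and differ only in the aryl group attached to it. In a functional assay on UACC-62 cells (Homo sapiens) for inhibition, read by sulforhodamine B assay, with a stated time of 48 h, tested at 10 uM (on this read-out lower numbers stand for less inhibition and higher numbers for more inhibition at the one concentration tested (going by the name of the read-out)), compound 1 `Fc1ccc(-c2cn3ccnc3c(-c3ccc4ncn(C5CCCCC5)c4c3)n2)cc1` gives 31%, compound 2 `CC(=O)c1ccc(-c2cn3ccnc3c(-c3ccc4ncn(C5CCCCC5)c4c3)n2)cc1` gives 18.5%, and compound 3 `Clc1ccc(-c2cn3ccnc3c(-c3ccc4ncn(C5CCCCC5)c4c3)n2)cc1` gives 30.5%. Compound 3 stands second highest of the three numbers: its nearest neighbour is compound 1, and a number 0.5 percentage points lower from compound 1 to compound 3 (within the scatter) lies within the scatter, while the further one is compound 2, where a number 12 percentage points higher from compound 2 to compound 3 (beyond the scatter) is beyond the scatter.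

Compound 4 `FC(F)(F)c1cccc(-c2cn3ccnc3c(-c3ccc4ncn(C5CCCCC5)c4c3)n2)c1` carries the change (3-(trifluoromethyl)phenyl in place of 4-chlorophenyl on an aromatic carbon). Among the compounds with values here, no measured step swaps a chloro for a trifluoromethyl, and none moves a substituent to another position of the phenyl ring, so the measured steps bear on this change only loosely: a number 0.5 percentage points lower from compound 1 to compound 3 (within the scatter) shows that one halogen for another on this ring changes little, and a number 12 percentage points higher from compound 2 to compound 3 (beyond the scatter) shows a modest gain when acetyl gives way to chloro. Within the data shown here, with no closer precedent, compound 4 is expected to show a number 0.5 percentage points lower from compound 3 to compound 4 (within the scatter), no step beyond the scatter. Compound 4 is therefore estimated at 30%, within a range from 15% to 45%.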

Compound 4, a percentage reported as inhibition, at one concentration (the size of the read-out at that concentration, not a potency): 4.33%
Compound 4: middle estimate off by 25.7 percentage points, on the high side, outside the stated range (below it).
By their numbers in this assay, from the lowest: compound 4; then compound 2; then compounds 3 and 1 (each within the scatter of the next).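

The aryl group on the shared core proves far less forgiving than the near-identical fluoro and chloro compounds suggested: in this assay there is a number 26.2 percentage points lower from compound 3 to compound 4 (beyond the scatter) and likewise a number 26.7 percentage points lower from compound 1 to compound 4 (beyond the scatter) on replacing the 4-substituted halophenyl groups. The 3-(trifluoromethyl)phenyl group also falls short of the 4-acetylphenyl compound, the lowest of the earlier three, with a number 14.2 percentage points lower from compound 2 to compound 4 (beyond the scatter) in the same read-out. No measurement at hand explains this drop.

Compound 4 changes both the group and its place on the phenyl ring at once, and the compounds shown do not separate these two changes. Also open, going by these compounds, is how an amine or a carboxylic acid on that ring would read in this assay on this core.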